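The source may report more compounds than this note shows. Statements on the series, on what has been measured and on what is new or still open speak of the compounds shown alone.

In a functional assay on A549 cells (Homo sapiens) for antiproliferative activity, read by MTT assay, with a stated time of 48 h (a higher number here means a weaker inhibitor, a lower number a stronger inhibitor), three compounds sharing one core differ only in the group on an oxygen on an aromatic ring. Compound 1 `COc1cc(-c2nnc3c(OC(C)C)cc(-c4ccc5[nH]ccc5c4)cn23)cc(OC)c1OC`, with isopropyl, gives 1250 nM. Compound 2 `COc1cc(-c2nnc3c(OCC(F)(F)F)cc(-c4ccc5[nH]ccc5c4)cn23)cc(OC)c1OC`, with 2,2,2-trifluoroethyl, gives 585 nM. Compound 3 `COc1cc(-c2nnc3c(OC4CC4)cc(-c4ccc5[nH]ccc5c4)cn23)cc(OC)c1OC`, with cyclopropyl, gives 198 nM, the lowest number of the three.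

Compound 4 `COc1cc(-c2nnc3c(OC4CN(C(C)(C)C)C4)cc(-c4ccc5[nH]ccc5c4)cn23)cc(OC)c1OC` changes this same place: 1-(tert-butyl)azetidin-3-yl in place of cyclopropyl on an oxygen on an aromatic ring. In words, 1-(tert-butyl)azetidin-3-yl stands in place of cyclopropyl. Within the data shown here, all the measured steps bear on this position, and each is modest: a 2.1-fold lower number from compound 1 to compound 2 (0.33 log units; beyond the scatter), a 3.0-fold lower number from compound 2 to compound 3 (0.47 log units; beyond the scatter) and a 6.3-fold lower number from compound 1 to compound 3 (0.80 log units; beyond the scatter). They show that the number responds to the group here, but none of them brings in a group containing nitrogen, so they guide the size of the step only loosely. A modest move to a higher number is expected, estimated as a 2.8-fold higher number from compound 3 to compound 4 (0.44 log units; beyond the scatter). In this assay, the estimated value for compound 4 is 550 nM, with an expected range of 140 nM to 2200 nM.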

Compound 4, half-maximal inhibitory concentration: > 10000 nM
Compound 4 ended at the assay's limit; the forecaster's own chance of this, stated with the estimate: 4%; middle value at least 18-fold (1.25 log units) away from the limit.
By their numbers in this assay, from the lowest: compound 3; then compound 2; then compound 1. At a limit, above all of these: compound 4.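

In this assay compound 4 stands at a limit of the assay, not at a measured number: the limit of > 10000 nM in this assay, at which 1 of the 4 values shown sits.

Its steps can therefore be read only as minimum sizes: an at least 50-fold higher number from compound 3 to compound 4 (1.70 log units; beyond the scatter), an at least 17-fold higher number from compound 2 to compound 4 (1.23 log units; beyond the scatter) and an at least 8.0-fold higher number from compound 1 to compound 4 (0.90 log units; beyond the scatter). Isopropyl, 2,2,2-trifluoroethyl and cyclopropyl had shown only modest steps among themselves, whereas 1-(tert-butyl)azetidin-3-yl shows that a change at this oxygen can carry the number to the limit of the assay.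

This single change brings in a four-membered ring, a ring nitrogen and a tert-butyl group together, and the compounds shown do not separate them. On these data alone, whether azetidin-3-yl without the tert-butyl group, 1-methylazetidin-3-yl or the oxygen-containing oxetan-3-yl would stay nearer compound 3 remains open.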